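The source may hold more compounds than are shown below. What is called first, only, known or untested is meant among the compounds shown, and "the series" means these compounds.

Measured so far:
- Compound 1 `CNC(=O)c1cc(C(=O)NC2CC2)cn(Cc2ccc(OC)cc2)c1=O`: >= 143 ug/mL
- Compound 2 `CNC(=O)c1ccc(=O)n(Cc2cc(Br)ccc2F)c1`: >= 143 ug/mL
- Compound 3 `CNC(=O)c1cc(C(=O)NCCCC2CNCCO2)cn(Cc2ccccc2)c1=O`: >= 194 ug/mL

The read-out here is a physicochemical assay for solubility; a higher number here means a more soluble compound, a lower number a less soluble compound. In this assay compound 1 gives >= 143 ug/mL, which is a limit of the assay and not a number. Within the data shown here, the same holds for the other two compounds, so the series so far offers no exact value. The three results fall at two limits: the limit of >= 143 ug/mL in this assay, at which 2 of the 3 values shown sit, and (the limit of >= 194 ug/mL in this assay, at which 1 of the 3 values shown sits). Compound 1 therefore has no numerical position within the set.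

The next compound is compound 4 `CNC(=O)c1cc(C(=O)NC2CC2)cn(Cc2ccc(F)cc2)c1=O`, which keeps the core of compound 1 and has fluoro in place of methoxy on an aromatic carbon. The same difference, cut one bond further out, reads 4-methoxyphenyl to 4-fluorophenyl.

Among the measured compounds shown here, no two measured compounds differ in one place, so the data give no measured size for this change. No shift beyond the scatter is expected in this assay, and a report at a limit is the likeliest outcome. The expected change is a step that the limit leaves unreadable from compound 1 to compound 4. For compound 4 the estimate is 150 ug/mL, with an expected range of 80 ug/mL to 200 ug/mL.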

Compound 4, solubility: >= 162 ug/mL
Compound 4 gave a limit, no number; the forecaster's own chance of this, stated with the estimate: 70%; middle value at least 1.0-fold (0.03 log units) from the limit.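

In this assay compound 4 gives >= 162 ug/mL, a limit of the assay and not a number. Compound 1 gives >= 143 ug/mL, also a limit. No step can be read between compound 1 and compound 4. The compounds shown leave open what fluoro in place of methoxy does in this assay.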